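Replacing a benzyl-type amine with a piperidinyl-ethyl amine

A few compounds are considered here, and "the series" means these few. Any claim that something is new, unique, unknown or untested is made for them only; others in the source may bear on it.

Measured so far:
compound 1, `CN(C)CCN(CCN(C)C)c1ccc(C(=O)N2CCc3ccc(OS(N)(=O)=O)cc3C2)cc1`, 15.9%
compound 2, `CCN(Cc1ccc(F)cc1)c1ccc(C(=O)N2CCc3ccc(OS(N)(=O)=O)cc3C2)cc1`, 91.2%

Going by the values given here, in an assay on HEK293 cells for inhibition of Steryl-sulfatase (Homo sapiens), tested at 1 uM (a lower number here means a weaker effect, a higher number a stronger effect of the compound at the concentration tested), compound 2 stands at the top of the two numbers known, with compound 1 far lower. Among the compounds with values here, the one measured step, a number 75.3 percentage points higher from compound 1 to compound 2 (beyond the scatter), shows how strongly the group on this aromatic carbon matters: a group built from two amine-bearing chains gave a weak effect, while ethyl(4-fluorobenzyl)amino gave a strong one. Compound 3, `CN(CCN1CCCCC1)c1ccc(C(=O)N2CCc3ccc(OS(N)(=O)=O)cc3C2)cc1`, has not yet been measured. It differs from compound 2 in one place: methyl(2-(piperidin-1-yl)ethyl)amino in place of ethyl(4-fluorobenzyl)amino on an aromatic carbon. Within the data shown here, the entering group again carries an amine-bearing chain, more like compound 1 than compound 2, so the single measured step argues for a drop in this assay, though with only one chain rather than two the drop may not be as large. The expected step is a number 51.2 percentage points lower from compound 2 to compound 3 (beyond the scatter). For compound 3 the estimate in this assay is therefore 40%, within a range from 15% to 70%.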

Compound 3, a percentage reported as inhibition, at one concentration (the size of the read-out at that concentration, not a potency): 26.8%
Compound 3: the middle estimate sits 13.2 percentage points above what was measured, within the range that was stated.
By their numbers in this assay, from the lowest: compound 1; then compound 3; then compound 2.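

Swapping ethyl(4-fluorobenzyl)amino for methyl(2-(piperidin-1-yl)ethyl)amino gives a number 64.4 percentage points lower from compound 2 to compound 3 (beyond the scatter) in this assay, so a second group with amine-bearing chains and no aromatic ring also ends up low, while the only group here with an aromatic ring stays high. Set against bis(2-(dimethylamino)ethyl)amino, the same group gives a number 10.9 percentage points higher from compound 1 to compound 3 (beyond the scatter), so one chain ending in a piperidine ring improves only modestly on two chains ending in dimethylamino. Nothing available here explains these differences.

The compounds shown leave open which part of ethyl(4-fluorobenzyl)amino carries the strong effect: the fluorine, the aromatic ring or the absence of a second amine. Benzyl(ethyl)amino, which lacks the fluorine, and ethyl(cyclohexylmethyl)amino, which has a non-aromatic ring instead, would help to separate these possibilities.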